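The source may report more compounds than this note shows. Statements on the series, on what has been measured and on what is new or still open speak of the compounds shown alone.

Measured in a functional assay on SK-MEL-2 cells (Homo sapiens) for cytotoxicity; a higher number here means a weaker inhibitor, a lower number a stronger inhibitor:
- Compound 1 `Cc1ccc(S(=O)(=O)N2CC(c3ccc(Br)cc3)NC2=O)cc1`: > 253000 nM (a limit of the assay, not a number)
- Compound 2 `O=C1NC(c2ccccc2)CN1S(=O)(=O)c1ccccc1`: 116000 nM
- Compound 3 `O=C1NC(c2ccc(Br)cc2)CN1S(=O)(=O)c1ccc(Cl)cc1`: 111000 nM

Among the compounds with values here, compound 3 stands within the scatter of compound 2, the only other compound with an exact number, so these two values give no order. Within the data shown here, the one measured step, an at least 2.2-fold lower number from compound 1 to compound 3 (0.35 log units; beyond the scatter), is chloro in place of methyl, which is a different place from the change followed here.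

Compound 4 `O=C1NC(c2ccccc2)CN1S(=O)(=O)c1ccc(Cl)cc1` has not yet been measured. It carries hydrogen in place of bromo on an aromatic carbon, para to a large group: hydrogen in place of bromo on an aromatic carbon. Among the measured compounds shown here, no measured step covers this change directly. The nearest guide is compound 2, which also bears phenyl instead of 4-bromophenyl and gives 116000 nM. In this assay, no step beyond the scatter is therefore expected, in either direction. The expected change is a 1.0-fold higher number from compound 3 to compound 4 (0.02 log units; within the scatter). For compound 4 the estimated value is 115000 nM, with an expected range of 55000 nM to 230000 nM.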

Compound 4, half-maximal inhibitory concentration: 1430 nM
For compound 4 the middle estimate is 80-fold (1.91 log units) above the measured one; the whole stated range lies above it.
By their numbers in this assay, from the lowest: compound 4; then compounds 3 and 2 (each within the scatter of the next). At a limit, above all of these: compound 1.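

In this assay, within the data shown here, the change from 4-bromophenyl to phenyl brings a 78-fold lower number from compound 3 to compound 4 (1.89 log units; beyond the scatter) and is the first measured step at this place. With phenyl kept, introducing the chloro brings an 81-fold lower number from compound 2 to compound 4 (1.91 log units; beyond the scatter) as well. Either single change away from compound 4 therefore returns the number to the high range of compounds 2 and 3, so the low number appears only where chloro and this hydrogen occur together.

The compounds shown leave open whether hydrogen in place of bromo would give a step of this size without the chloro, and whether fluoro or a methoxy group at this place would keep the low number of compound 4. Nothing measured here bears on what lies behind these steps.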